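Swapping chloro for fluoro on the benzylsulfanyl arm

The source may hold more compounds than are shown below. What is called first, only, known or untested is meant among the compounds shown, and "the series" means these compounds.

Measured compounds:
- compound 1, `CC1=C(C(=O)Nc2ccc(Br)cc2)C(c2ccc(Cl)cc2Cl)N=C(SCc2ccc(F)cc2)N1`: 16.9%
- compound 2, `COc1ccc(C2N=C(SCc3cccc(Cl)c3)NC(C)=C2C(=O)Nc2ccc(Br)cc2)cc1`: 15.4%
- compound 3, `COc1ccc(C2N=C(SCc3ccc(Cl)cc3)NC(C)=C2C(=O)Nc2ccc(Br)cc2)cc1`: 12.3%

All three were tested in a functional assay on the whole organism (artery, strain albino) with Rattus norvegicus as the target, with a stated time of 60 min, at a dose of 10 mg/kg by the oral route; on this read-out lower numbers stand for less inhibition and higher numbers for more inhibition at the one dose given (going by the name of the read-out). Compound 3 gives 12.3%, the lowest of the three numbers, but its distance to compound 2 and to compound 1 lies within the scatter of this kind of measurement, so no ordering among them can be claimed.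

The unmeasured compound 4, `COc1ccc(C2N=C(SCc3ccc(F)cc3)NC(C)=C2C(=O)Nc2ccc(Br)cc2)cc1`, differs from compound 3 in one place: fluoro in place of chloro on an aromatic carbon.

Going by the values given here, only one measured step touches the benzylsulfanyl arm: a number 3.1 percentage points lower from compound 2 to compound 3 (within the scatter). Moving the chlorine around the ring left the read-out essentially unchanged. Compound 4 shares its 4-fluorobenzyl group with compound 1, which carries it on a different core; in this assay compound 1 gives 16.9%, a number within the scatter of compound 3. Nothing here suggests that a change on this ring moves the read-out.

For compound 4 the expected step is therefore a number 1.7 percentage points higher from compound 3 to compound 4 (within the scatter), no shift beyond the scatter. Compound 4 is estimated to give 14%, with a range from 5% to 24%.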

Compound 4, a percentage reported as inhibition, in the whole organism at one dose (the size of the read-out at that dose, not a potency): 8.7%
Beside the measured number, compound 4's estimate is 5.3 percentage points above it; the range from low to high includes it.
By their numbers in this assay, from the lowest: compounds 4, 3, 2 and 1 (each within the scatter of the next).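

In this assay, the exchange of one halogen for another on the benzyl ring can now be read directly: with the place on the ring unchanged, para to a large group, the result is a number 3.6 percentage points lower from compound 3 to compound 4 (within the scatter) and so gives no sign that fluoro and chloro differ here. The picture stays the same when the halogen and its place change together (a number 6.7 percentage points lower from compound 2 to compound 4 (within the scatter)) and when the core of compound 1 is compared, where the exchange is 4-methoxyphenyl in place of 2,4-dichlorophenyl on a saturated ring carbon (a number 8.2 percentage points lower from compound 1 to compound 4 (within the scatter)). Nothing measured here speaks to what lies behind these small differences.

On these data alone, all four compounds lie within the scatter of their neighbours in the ranking, so it remains open whether any change on this benzyl ring can move the read-out at all. Going by these compounds alone, only halogens have been seen at this place so far, and a carboxylic acid or an amine on the same ring would show whether a very different group there moves the read-out beyond the scatter.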